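A few compounds are considered here, and "the series" means these few. Any claim that something is new, unique, unknown or untested is made for them only; others in the source may bear on it.

Compound 1 `COC(=O)c1nc(C)n(-c2ccc(OC)cc2)n1` and compound 2 `COC(=O)c1nc(C)n(-c2ccc(Cl)cc2)n1` share one core and differ at a single aromatic carbon. In a functional assay on Jurkat cells (Homo sapiens) for inhibition, read by MTT assay, with a stated time of 72 h (on this read-out higher numbers stand for weaker inhibition of growth and lower numbers for stronger inhibition of growth), compound 1 reaches only a limit of the assay, > 100000 nM. In this assay compound 2 gives 65900 nM, the only number shown. The other value, that of compound 1, is a limit of the assay, as stated in the limit of > 100000 nM in this assay, at which 1 of the 2 values shown sits. Going by the values given here, the single measured step, an at least 1.5-fold lower number from compound 1 to compound 2 (0.18 log units; that floor lies within the scatter), is therefore the only guide. Compound 3 `COC(=O)c1nc(C)n(-c2ccc(F)cc2)n1` carries fluoro in place of chloro on an aromatic carbon. Among the compounds with values here, no measured step concerns a fluoro group, so the exchange of one halogen for another can only be weighed against that one step, whose floor lies within the scatter. With so slight a precedent, compound 3 is expected to stay close to its neighbour, perhaps with a somewhat higher number, at an estimated 90000 nM with a range from 40000 nM to 200000 nM. The expected step is a 1.4-fold higher number from compound 2 to compound 3 (0.14 log units; within the scatter).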

Compound 3, concentration for 50% growth inhibition: 8700 nM
Compound 3: middle estimate off by 10-fold (1.01 log units), on the high side; measured number outside the range, below it.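

In this assay, going by these compounds alone, the identity of the halogen on this aromatic carbon, para to a large group, turns out to matter: fluoro in place of chloro gives a 7.6-fold lower number from compound 2 to compound 3 (0.88 log units; beyond the scatter) and is the first step here to clear the scatter. Fluoro in place of methoxy gives an at least 11-fold lower number from compound 1 to compound 3 (1.06 log units; beyond the scatter) and shows that this position responds to the group it carries, which the step from methoxy to chloro could not show. That step is only a floor, since compound 1 stands at a limit of the assay: the limit of > 100000 nM in this assay, at which 1 of the 3 values shown sits.

Going by these compounds, what an amine, a hydroxyl group or a trifluoromethyl group would do on this carbon remains open. So does the effect of a carboxylic acid or an amide in place of the methyl ester on the shared core.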